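A Nitrile in Place of a Methyl on an Anilide

The source may hold more compounds than are shown below. What is called first, only, known or untested is meant among the compounds shown, and "the series" means these compounds.

Measured compounds, in a functional assay on A549 cells (Homo sapiens) for antiproliferative activity, read by MTT assay, with a stated time of 72 h; a higher number here means a weaker inhibitor, a lower number a stronger inhibitor:
Compound 1 `O=C(Nc1ccccc1NC(=O)C(Cl)Cl)C(Cl)Cl` gives 131000 nM.
Compound 2 `Cc1cccc(NC(=O)C(Cl)Cl)c1` gives 41100 nM.

Of these two numbers compound 2 holds the lowest. Its nearest neighbour, compound 1, sits at a higher number, and that gap lies beyond the usual scatter. Compound 3 `N#Cc1cccc(NC(=O)C(Cl)Cl)c1` differs from compound 2 in one place: cyano in place of methyl on an aromatic carbon. Among the measured compounds shown here, no measured pair shows a change of this kind, so the size of its effect is unknown. The expected step from this change is none beyond the scatter, as the estimated step of a 1.0-fold lower number from compound 2 to compound 3 (0.01 log units; within the scatter) expresses. Compound 3 is therefore estimated at 40000 nM, within a range from 14000 nM to 115000 nM.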

Compound 3, half-maximal inhibitory concentration: 66500 nM
For compound 3 the middle estimate is 1.7-fold (0.22 log units) below the measured one; low and high end bracket the measured number.
By their numbers in this assay, from the lowest: compounds 2, 3 and 1 (each within the scatter of the next, the first and the last beyond it).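

Cyano in place of methyl gives a 1.6-fold higher number from compound 2 to compound 3 (0.21 log units; within the scatter) on this aromatic carbon, the first measured case of this change. The swap adds one heavy atom and a hydrogen-bond acceptor, yet the two compounds cannot be told apart in this read-out, so at this position these two groups are interchangeable within the scatter. Nothing measured here explains this result.

Open, as far as these compounds go, is whether an amine, a carboxylic acid or a longer chain on this carbon would move the number beyond the scatter. From the compounds shown here alone, whether cyano would behave the same way elsewhere on the ring also remains unknown.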